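Methyl added on the central ring of compound 1

The compounds below may be only part of what the source reports. "The series", "measured", "known", "first", "only" and "open" are said of these compounds alone.

The series consists of diaryl ureas on one shared core. Compound 1 `CNc1cc(Oc2ccc(NC(=O)Nc3cccc(C(F)(F)F)c3)cc2)ncn1` carries a methylamino group and in an assay on isolated protein for inhibition of serine/threonine-protein kinase TNNI3K (Homo sapiens) (a lower number here means a stronger inhibitor, a higher number a weaker inhibitor), compound 1 gives 40 nM, the lowest of the three numbers measured. Compound 2 `O=C(Nc1ccc(Oc2cc(O)ncn2)cc1)Nc1cccc(C(F)(F)F)c1` has hydroxy in its place and gives 3200 nM; compound 3 `COc1cc(Oc2ccc(NC(=O)Nc3cccc(C(F)(F)F)c3)cc2)ncn1` has methoxy and gives 4000 nM. The steps of an 80-fold higher number from compound 1 to compound 2 (1.90 log units; beyond the scatter) and a 100-fold higher number from compound 1 to compound 3 (2.00 log units; beyond the scatter) are both large, whereas a 1.3-fold higher number from compound 2 to compound 3 (0.10 log units; within the scatter) stays within the scatter. Compound 4 `CNc1cc(Oc2ccc(NC(=O)Nc3cccc(C(F)(F)F)c3)cc2C)ncn1` keeps the methylamino group of compound 1 and differs from it only in methyl in place of hydrogen on an aromatic carbon. None of the three measured steps bears on this change: each varies the methylamino group, not the six-membered aromatic ring of carbon only that receives the entering methyl. Nothing measured speaks to this change; the range is therefore kept wide. Compound 4 is expected to give about 60 nM, between 15 nM and 250 nM. The expected step of a 1.5-fold higher number from compound 1 to compound 4 (0.18 log units; within the scatter) is no change beyond the scatter.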

Compound 4, half-maximal inhibitory concentration: <= 10 nM
Compound 4: no number, only a limit (the forecaster's own chance of this, stated with the estimate: 2%); middle value at least 6.0-fold (0.77 log units) from the limit.
By their numbers in this assay, from the lowest: compound 1; then compounds 2 and 3 (each within the scatter of the next). At a limit, below all of these: compound 4.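

Among these compounds, the earlier compounds varied only the methylamino group, so this is the first reading on the six-membered aromatic ring of carbon only, ortho to a (6-(methylamino)pyrimidin-4-yl)oxy group. In this assay, methyl in place of hydrogen at this position gives an at least 4.0-fold lower number from compound 1 to compound 4 (0.60 log units; beyond the scatter), so this single added carbon lowers the number by more than the scatter. Compound 4 gives <= 10 nM, which is a limit of the assay and not a number: the limit of <= 10 nM in this assay, at which 1 of the 4 values shown sits.

Open, as far as these compounds go, is whether the methyl gives a similar step with hydroxy or methoxy in place of the methylamino group, as in compound 2 and compound 3, which carry hydrogen at this position. Also open, from the compounds shown here alone, is how an ethyl group, a chlorine atom or a methoxy group at this position compares with the methyl of compound 4.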